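This account rests on a few compounds, and the source may have more. Where it says the series, first, only, none or still open, it means among the compounds named here.

Values in an ADME assay on NCM460 cells (Homo sapiens) for cytotoxicity, read by CCK-8 assay, with a stated time of 48 h; on this read-out higher numbers stand for weaker inhibition and lower numbers for stronger inhibition:
- compound 1 `COc1ccc(/C=C\c2cc(OC)c(OC)c(OC)c2)cc1OCc1ccc(CN2CCCCC2C(=O)O)cc1`: > 50000 nM (a limit)
- compound 2 `COc1ccc(/C=C\c2cc(OC)c(OC)c(OC)c2)cc1OCc1ccc(CNCCO)cc1`: 39000 nM
- compound 3 `COc1ccc(/C=C\c2cc(OC)c(OC)c(OC)c2)cc1OCc1ccc(CN2CC[C@H](O)C2)cc1`: 51000 nM

Among the compounds with values here, compound 3 has only one numeric neighbour, and the two sit within the scatter: a 1.3-fold higher number from compound 2 to compound 3 (0.12 log units; within the scatter).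

Compound 4 `COc1ccc(/C=C\c2cc(OC)c(OC)c(OC)c2)cc1OCc1ccc(CN2CC[C@@H](C(=O)O)C2)cc1` is not yet measured. It carries 3-carboxypyrrolidin-1-yl in place of 3-hydroxypyrrolidin-1-yl on a saturated chain carbon bound to an aromatic carbon.

Within the data shown here, compound 1 is the only measured member with a carboxy group, and its > 50000 nM is a limit, not a number. The closest guides are therefore its two steps. One gives only a floor that lies within the scatter: an at least 1.2-fold lower number from compound 1 to compound 2 (0.10 log units; that floor lies within the scatter). The other cannot be sized: a step that the limit leaves unreadable from compound 1 to compound 3. Neither shows that a carboxy group moves the value by a readable amount, so no step beyond the scatter is expected, with at most a slight drift toward a higher number. The expected step is a 1.1-fold higher number from compound 3 to compound 4 (0.03 log units; within the scatter). A report of only a limit would also be unsurprising for the unmeasured compound. For compound 4 the estimated value is 55000 nM, with an expected range of 28000 nM to 110000 nM.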

Compound 4, half-maximal inhibitory concentration: > 50000 nM
Compound 4: a limit, no number (the forecaster's own chance of this, stated with the estimate: 50%); the middle value lies beyond the limit too.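

Compound 4 gives a second case, after compound 1, of a carboxy-bearing group on the saturated chain carbon bound to an aromatic carbon that returns a limit and not a number in this assay. Among the compounds shown, only these two carboxy compounds end at a limit, and neither compound 2 nor compound 3 does. Of the new steps, only a floor can be read, an at least 1.2-fold higher number from compound 2 to compound 4 (0.10 log units; that floor lies within the scatter), so no separation beyond the scatter is shown, while the steps from compound 3 to compound 4 and from compound 1 to compound 4 cannot be read, and both carboxy compounds share one limit: the limit of > 50000 nM in this assay, at which 2 of the 4 values shown sit.

From the compounds shown here alone, how far compound 1 and compound 4 lie past that limit stays open, so the size of any change on moving from 3-hydroxypyrrolidin-1-yl to 3-carboxypyrrolidin-1-yl remains unknown. Also open, going by these compounds, is whether a dimethylamino group or a longer chain ending in a carboxylic acid at this place would give a value that stands clear of the scatter around compound 2.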